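The compounds below may be only part of what the source reports. "The series", "measured", "known", "first", "only" and "open" are said of these compounds alone.

Compound 1 `CC(=O)Nc1cc(-c2c(Nc3cc[nH]n3)nc3cccnn23)nc(C)n1` gives the higher of the two numbers recorded in an in vivo ADME assay on the whole organism for metabolic stability, with Rattus norvegicus as the target, at a dose of 0.5 mg/kg by the intravenous route; a higher number here means that the compound lasts longer, a lower number that the compound disappears faster: compound 1 gives 0.82 h, while compound 2 `CNc1cc(-c2c(Nc3cc[nH]n3)nc3cccnn23)nc(C)n1` gives 0.26 h. For the measured compounds named here, the only measured step, a 3.2-fold lower number from compound 1 to compound 2 (0.50 log units; beyond the scatter), concerns the acetyl nitrogen. Compound 3 `CC(=O)Nc1cc(-c2c(Nc3ccn(C)n3)nc3cccnn23)nc(C)n1` differs from compound 1 elsewhere: methyl in place of hydrogen on an aromatic nitrogen. Going by the values given here, no measured step touches this ring nitrogen, so the acetyl-to-methyl step bears on it only loosely, and a step within the scatter, in no firm direction, is expected, a 1.2-fold lower number from compound 1 to compound 3 (0.07 log units; within the scatter). The estimate for compound 3 in this assay is therefore 0.7 h, ranging from 0.3 h to 1.6 h.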

Compound 3, half-life: 0.39 h
Compound 3: middle estimate off by 1.8-fold (0.25 log units), on the high side, and the stated range covers the measured number.
By their numbers in this assay, from the lowest: compounds 2 and 3 (each within the scatter of the next); then compound 1.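

In this assay the aromatic nitrogen of the 1H-pyrazol-3-yl group proves to be a position that matters: methyl in place of hydrogen there gives a 2.1-fold lower number from compound 1 to compound 3 (0.32 log units; beyond the scatter) on its own. The number therefore responds to a change away from the acetyl nitrogen as well, and a methyl alone is enough to move it beyond the scatter. Nothing at hand explains this drop. Going by these compounds, whether a longer chain such as ethyl on this ring nitrogen would act in the same way remains open. So does the effect of this methyl when paired with the methylamino group of compound 2.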